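A few compounds are considered here, and "the series" means these few. Any claim that something is new, unique, unknown or untested is made for them only; others in the source may bear on it.

Three compounds share one core and differ only in the group carried on an oxygen on a saturated carbon. Compound 1 `Cc1nn(-c2ncnc3nc[nH]c23)c2c1C(OCC(=O)c1ccc(F)cc1)CC(=O)N2` gives 3 nM in a functional assay on HEK293 cells for agonist activity at G-protein coupled receptor 39 (Homo sapiens), read by scintillation proximity assay and inositol phosphate accumulation, with a stated time of 75 min, in the presence of a further agent that is not named here; a higher number here means that more compound is needed for the effect, a lower number that less compound is needed; compound 2 `Cc1nn(-c2ncnc3nc[nH]c23)c2c1C(OC1CCCC1)CC(=O)N2` gives 2 nM; compound 3 `Cc1nn(-c2ncnc3nc[nH]c23)c2c1C(OC(=O)c1ccc(F)cc1)CC(=O)N2` gives 4 nM. Compound 3 holds the highest of these three numbers, yet its gaps to compound 1 and compound 2 both fall within the scatter. Compound 4 `Cc1nn(-c2ncnc3nc[nH]c23)c2c1C(OCc1ccccc1F)CC(=O)N2` differs from compound 3 by 2-fluorobenzyl in place of (4-fluorophenyl)carbonyl on an oxygen on a saturated carbon. All three measured steps concern this same position: a 1.5-fold lower number from compound 1 to compound 2 (0.18 log units; within the scatter), a 1.3-fold higher number from compound 1 to compound 3 (0.12 log units; within the scatter) and a 2.0-fold higher number from compound 2 to compound 3 (0.30 log units; within the scatter). Since none of these exchanges moved the number beyond the scatter, the step to compound 4 is also expected to be small, no change at the digits printed from compound 3 to compound 4 (within the scatter). Compound 4 is therefore estimated at 4 nM, in a range from 1.5 nM to 12 nM.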

Compound 4, half-maximal effective concentration: 4 nM
Estimate against measurement, compound 4: no gap at the digits printed; measured number inside the range.
By their numbers in this assay, from the lowest: compounds 2, 1, 3 and 4 (each within the scatter of the next).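

Compound 4 has a 2-fluorobenzyl group with no carbonyl, and this exchange, which also takes away the hydrogen-bond acceptor of the leaving group, barely registers (no change at the digits printed from compound 3 to compound 4 (within the scatter)). The other new steps are also small (a 2.0-fold higher number from compound 2 to compound 4 (0.30 log units; within the scatter); a 1.3-fold higher number from compound 1 to compound 4 (0.12 log units; within the scatter)), so among these four compounds, the oxygen accepts a benzyl group as readily as the carbonyl-bearing groups and cyclopentyl. Nothing shown gives a reason for this tolerance. Going by these compounds, whether it extends to an amine or a carboxylic acid on this oxygen remains open, as does the outcome with a plain benzyl group.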